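A few compounds are considered here, and "the series" means these few. Any claim that something is new, unique, unknown or untested is made for them only; others in the source may bear on it.

Measured in a functional assay on B16-F10 cells (Mus musculus) for inhibition, read by MTT assay, with a stated time of 72 h (on this read-out lower numbers stand for stronger inhibition of growth and higher numbers for weaker inhibition of growth), so far:

Compound 1 `CC(C)=CC(=O)NC(=N)N` gives 92800 nM
Compound 2 `CC(C)=CCC/C(C)=C/C(=O)NC(=N)NC(=O)C=C(C)C` gives 25000 nM
Compound 3 `CC(C)=CCC/C(C)=C/C(=O)NC(=N)NC(=O)/C=C(\C)CCC=C(C)C` gives 23800 nM

Compound 2 stands level with compound 3 (a 1.1-fold lower number from compound 2 to compound 3 (0.02 log units; within the scatter)), and its value lies beyond the scatter from the higher number of compound 1. Compound 4 `CC(C)=CCC/C(C)=C/C(=O)NC(=N)N` comes from compound 2 by one change (hydrogen in place of (2-methylprop-1-en-1-yl)carbonyl on an amine nitrogen): hydrogen in place of (2-methylprop-1-en-1-yl)carbonyl on an amine nitrogen. Among the compounds with values here, no measured step makes this change. Within the data shown here, the one measured step, from compound 2 to compound 3, alters another part and stays within the scatter. The nearest guide is compound 1, which also has hydrogen on that nitrogen and gives 92800 nM in this assay as a higher number. The expected change is a 2.0-fold higher number from compound 2 to compound 4 (0.30 log units; within the scatter) towards weaker inhibition. In this assay the estimate for compound 4 is 50000 nM with an expected range of 22000 nM to 100000 nM around it.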

Compound 4, concentration for 50% growth inhibition: 17100 nM
Compound 4: the middle estimate sits 2.9-fold (0.47 log units) above what was measured, and the stated range ends above it.
By their numbers in this assay, from the lowest: compounds 4, 3 and 2 (each within the scatter of the next); then compound 1.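

In this assay, hydrogen in place of (2-methylprop-1-en-1-yl)carbonyl on the amine nitrogen gives a 1.5-fold lower number from compound 2 to compound 4 (0.16 log units; within the scatter), so compound 2 shows no measurable gain from carrying that group. The 3-methylbut-2-en-1-yl change, silent where the nitrogen carries the acyl group, does count where that nitrogen carries hydrogen, with a 5.4-fold lower number from compound 1 to compound 4 (0.73 log units; beyond the scatter). The effect of this change therefore differs with what the nitrogen carries: the same change on two cores in this assay, a 1.1-fold lower number (0.02 log units; within the scatter) from compound 2 to compound 3 and a 5.4-fold lower number (0.73 log units; beyond the scatter) from compound 1 to compound 4, 5.2-fold (0.71 log units) apart, beyond the scatter of two such steps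

The compounds shown leave open whether a longer chain in place of 3-methylbut-2-en-1-yl would lower the number further on the core of compound 4. They also leave open how a smaller acetyl group would behave on that amine nitrogen.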